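Swapping the ether linker of a thiadiazole amide for a benzyl

The source may report more compounds than this note shows. Statements on the series, on what has been measured and on what is new or still open speak of the compounds shown alone.

Measured so far:
compound 1 `Cc1ccc(C)c(OCc2nnc(C(=O)Nc3ccc(CCC(=O)O)cc3)s2)c1` gives 1530 nM in a functional assay on CHO cells for agonist activity at Free fatty acid receptor 1 (Homo sapiens), read by FLIPR and calcium flux, tested at 1 uM; on this read-out lower numbers stand for an effect already at smaller amounts and higher numbers for an effect only at larger amounts of compound
compound 2 `Cc1ccccc1OCc1nnc(C(=O)Nc2ccc(CCC(=O)O)cc2)s1` gives 1520 nM in this assay

Compound 2 holds the lowest of the two numbers in this assay, though its step of a 1.0-fold lower number from compound 1 to compound 2 (0.00 log units; within the scatter) is within the scatter. Compound 3 `O=C(O)CCc1ccc(NC(=O)c2nnc(Cc3cccc(Cl)c3)s2)cc1` differs by 3-chlorophenyl in place of 2-methylphenoxy on a saturated chain carbon bound to an aromatic carbon. For the measured compounds named here, no measured step bears on this change; the only step known, a 1.0-fold lower number from compound 1 to compound 2 (0.00 log units; within the scatter), touches a methyl elsewhere and was flat. Compound 3 is therefore estimated without a directional pull, a step of a 1.2-fold higher number from compound 2 to compound 3 (0.07 log units; within the scatter) and a wide range. Compound 3 is expected at 1800 nM, between 450 nM and 7000 nM.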

Compound 3, half-maximal effective concentration: 2390 nM
For compound 3 the middle estimate is 1.3-fold (0.12 log units) below the measured one; the range from low to high includes it.
By their numbers in this assay, from the lowest: compounds 2, 1 and 3 (each within the scatter of the next).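

In this assay, the change at the saturated chain carbon bound to an aromatic carbon is larger than the earlier methyl swap, yet it stays just as unresolved: 3-chlorophenyl in place of 2-methylphenoxy gives a 1.6-fold higher number from compound 2 to compound 3 (0.20 log units; within the scatter), and in place of 2,5-dimethylphenoxy it gives a 1.6-fold higher number from compound 1 to compound 3 (0.19 log units; within the scatter). The oxygen of the phenoxy group can therefore leave and a chlorine enter with no change beyond the scatter. Nothing at hand explains this result. Still open, on these data alone, is whether an unsubstituted benzyl or a dimethylamino group at this position would keep the number in the same range.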